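The compounds below may be only part of what the source reports. "The series", "measured", "known", "first", "only" and "open" are said of these compounds alone.

In an ADME assay on HaCaT cells (Homo sapiens) for cytotoxicity, read by MTT assay, with a stated time of 72 h (on this read-out higher numbers stand for weaker inhibition and lower numbers for stronger inhibition), three compounds sharing one core have been measured: compound 1 (`CCCCNC1=CC(=O)C=C(C(C)(C)C)C1=O`) gives 11000 nM, compound 2 (`CC(C)(C)C1=CC(=O)C=C(NCc2ccccc2)C1=O`) gives 21000 nM, and compound 3 (`CNC1=CC(=O)C=C(C(C)(C)C)C1=O`) gives 10000 nM. Compound 3 stands level with compound 1, with a 1.1-fold lower number from compound 1 to compound 3 (0.04 log units; within the scatter), and lies modestly below compound 2, with a 2.1-fold lower number from compound 2 to compound 3 (0.32 log units; beyond the scatter). Compound 4 (`CC(C)(C)C1=CC(=O)C=CC1=O`) loses the amine substituent altogether: hydrogen in place of methylamino on a double-bonded ring carbon. The measured steps bear on this only partly. Together with a 1.9-fold higher number from compound 1 to compound 2 (0.28 log units; within the scatter), they vary only the group on the amine nitrogen, and none exceeds a modest size. None of them removes the nitrogen, so the data do not size this change directly. A modest step toward a lower number in this assay is expected, though a result within the scatter remains possible. The estimated change is a 2.2-fold lower number from compound 3 to compound 4 (0.35 log units; beyond the scatter). The expected value for compound 4 is 4500 nM, with an estimated range of 1500 nM to 14000 nM.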

Compound 4, half-maximal inhibitory concentration: 95000 nM
Beside the measured number, compound 4's estimate is 21-fold (1.32 log units) below it, outside the stated range (above it).
By their numbers in this assay, from the lowest: compounds 3, 1 and 2 (each within the scatter of the next, the first and the last beyond it); then compound 4.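

In this assay, taking the whole amine substituent off the double-bonded ring carbon raises the number, toward weaker inhibition, with a 9.5-fold higher number from compound 3 to compound 4 (0.98 log units; beyond the scatter) and an 8.6-fold higher number from compound 1 to compound 4 (0.94 log units; beyond the scatter). The earlier compounds shown here varied only the group on the nitrogen, and even their largest step, a 2.1-fold lower number from compound 2 to compound 3 (0.32 log units; beyond the scatter), is much smaller, so at this carbon, having an amine substituent counts for more than which group its nitrogen carries. Nothing here accounts for the rise. As far as these compounds go, whether the nitrogen itself is what matters stays open, since a methyl or methoxy group in place of methylamino, or a dimethylamino group lacking the amine hydrogen, could separate the presence of a substituent from that of the nitrogen and its hydrogen. From the compounds shown here alone, the tert-butyl group is also constant throughout, so the effect of replacing it with a methyl group remains open too.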